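The source may report more compounds than this note shows. Statements on the series, on what has been measured and on what is new or still open speak of the compounds shown alone.

Among the measured compounds shown here, in a functional assay on NCI-H460 cells (Homo sapiens) for antiproliferative activity, read by XTT assay, with a stated time of 72 h (a lower number here means a stronger inhibitor, a higher number a weaker inhibitor), compound 3 `COc1ccc(-c2cc3ccccc3nc2/C=C/C(=O)c2ccco2)cc1` gives 6430 nM, the lowest of the two numbers measured so far. Compound 2 `COc1ccc(-c2cc3ccccc3nc2/C=C/C(=O)c2ccc(OC)c(OC)c2)cc1` gives 7540 nM, and the step of a 1.2-fold lower number from compound 2 to compound 3 (0.07 log units; within the scatter) stays within the scatter. Compound 1 `COc1ccc(C(=O)/C=C/c2nc3ccccc3cc2-c2ccc(OC)cc2)cc1` gives > 10000 nM in this assay, which is a limit and not a number; this is the limit of > 10000 nM in this assay, at which 1 of the 3 values shown sits. The step of an at least 1.5-fold lower number from compound 1 to compound 3 (0.19 log units; that floor lies within the scatter) therefore carries only a floor. Compound 4 `COc1ccc(-c2cc3ccccc3nc2/C=C/C(=O)c2c[nH]c3ccccc23)cc1` differs from compound 3 by 1H-indol-3-yl in place of furan-2-yl on a carbonyl carbon. The two earlier changes on the carbonyl carbon, from compound 1 and from compound 2 to compound 3, moved this assay by little, so a step of a 1.3-fold lower number from compound 3 to compound 4 (0.11 log units; within the scatter) is expected, with no direction clearly beyond the scatter. Compound 4 is accordingly estimated at 5000 nM, within a range of 1500 nM to 15000 nM.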

Compound 4, half-maximal inhibitory concentration: 8010 nM
Compound 4: middle estimate off by 1.6-fold (0.20 log units), on the low side; the range from low to high includes it.
By their numbers in this assay, from the lowest: compounds 3, 2 and 4 (each within the scatter of the next). At a limit, above all of these: compound 1.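

On this carbonyl carbon, 1H-indol-3-yl brings a six-membered aromatic ring and a hydrogen-bond donor that furan-2-yl lacks, yet this assay shows only a 1.2-fold higher number from compound 3 to compound 4 (0.10 log units; within the scatter) and a 1.1-fold higher number from compound 2 to compound 4 (0.03 log units; within the scatter). Adding this ring and this donor therefore gives no change that can be told from the scatter. Compound 1 stands at a limit and not a number, so only a floor can be read, an at least 1.2-fold lower number from compound 1 to compound 4 (0.09 log units; that floor lies within the scatter), and one end of the comparison stays unfixed: the limit of > 10000 nM in this assay, at which 1 of the 4 values shown sits.

Every compound shown carries an aromatic ring on this carbon. Going by these compounds, whether an amine or a simple alkyl chain there would move the number beyond the scatter stays open.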